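Furan to thiophene on the amide-bound methylene

A few compounds are considered here, and "the series" means these few. Any claim that something is new, unique, unknown or untested is made for them only; others in the source may bear on it.

Compound 1 `N[C@H]1CC[C@H](Nc2c(C(=O)NCc3ccco3)nc(Br)c3cccnc23)CC1` carries a furan-2-yl group on the saturated chain carbon bound to the amide-type nitrogen. In a functional assay on HEY cells (Homo sapiens) for cytotoxicity, read by MTT assay, with a stated time of 72 h (on this read-out higher numbers stand for weaker inhibition and lower numbers for stronger inhibition), compound 1 gives > 10000 nM, which is a limit of the assay and not a number. Compound 1 is the entry that stands at the limit of > 10000 nM in this assay, at which 1 of the 2 values shown sits. Compound 2 `N[C@H]1CC[C@H](NC(=O)c2nc(Br)c3cccnc3c2NCc2ccc(F)cc2)CC1` is the second measured member; in this assay compound 2 gives 7100 nM. Within the data shown here, no step between measured compounds that differ in one place is available in this set.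

Compound 3 `N[C@H]1CC[C@H](Nc2c(C(=O)NCc3cccs3)nc(Br)c3cccnc23)CC1` is not yet measured in this assay. The change from compound 1 to compound 3 is thiophen-2-yl in place of furan-2-yl on a saturated chain carbon bound to an amide-type nitrogen. No step beyond the usual scatter is expected from this exchange; the step that the limit leaves unreadable from compound 1 to compound 3 is estimated to stay within it. Compound 3 is therefore expected to give about 12000 nM in this assay, with a range from 5000 nM to 30000 nM, and a fair chance that again only a limit is reported.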

Compound 3, half-maximal inhibitory concentration: 11000 nM
Beside the measured number, compound 3's estimate is 1.1-fold (0.04 log units) above it, and the stated range covers the measured number.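

No step from compound 1 to compound 3 can be read, because the value of compound 1 is a limit of the assay and not a number: the limit of > 10000 nM in this assay, at which 1 of the 3 values shown sits.

The compounds shown leave open whether thiophen-2-yl in place of furan-2-yl on a saturated chain carbon bound to an amide-type nitrogen changes the result in this assay at all.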